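Swapping a pyridine for a thiophene on a hydrazone

The source may hold more compounds than are shown below. What is called first, only, known or untested is meant among the compounds shown, and "the series" means these compounds.

Measured compounds and their values:
- compound 1, `C/C(=N\NC(=O)COc1cccc2cccnc12)c1ccccn1`: > 100000 nM
- compound 2, `Brc1ccc(-c2csnn2)cc1`: 68100 nM
- compound 3, `Clc1ccc(-c2c[se]nn2)cc1`: 57100 nM

Of the compounds shown here, three have been tested in an ADME assay on MCF7 cells (Homo sapiens) for cytotoxicity, read by MTT assay, with a stated time of 48 h; a higher number here means a weaker inhibitor, a lower number a stronger inhibitor. Compound 2 gives 68100 nM and compound 3 gives 57100 nM, each a number in its own right. For compound 1 the result is only a limit of the assay, not a number, and this is the limit of > 100000 nM in this assay, at which 1 of the 3 values shown sits. Compound 1 therefore stands at the weak end of what this assay can report, with no measured value of its own.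

The next compound, compound 4, `C/C(=N\NC(=O)COc1cccc2cccnc12)c1cccs1`, keeps the shared core of compound 1 and changes one group: thiophen-2-yl in place of pyridin-2-yl on a carbon with a double bond to nitrogen. Within the data shown here, no measured pair shows the effect of this change. Since compound 1 sits at the limit, the step in this assay from compound 1 to compound 4 is expected to be a number no higher from compound 1 to compound 4 (the limit leaves the size open), that is, no clear move beyond the scatter. Compound 4 is therefore estimated at 100000 nM, within a range from 30000 nM to 300000 nM.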

Compound 4, half-maximal inhibitory concentration: > 100000 nM
Compound 4 was reported as a limit; the forecaster's own chance of this, stated with the estimate: 60%; the middle value lies on the limit itself.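

Compound 1 and compound 4 each give a limit rather than a number, so no step can be read between them: the limit of > 100000 nM in this assay, at which 2 of the 4 values shown sit.

The compounds shown leave open whether thiophen-2-yl in place of pyridin-2-yl changes the strength of the shared core at all, and by how much.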